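A few compounds are considered here, and "the series" means these few. Any claim that something is new, unique, unknown or untested is made for them only; others in the source may bear on it.

Three compounds have been measured in a functional assay on HL-60 cells (Homo sapiens) for inhibition, read by CCK-8 assay, with a stated time of 48 h, tested at 20 uM; on this read-out lower numbers stand for less inhibition of growth and higher numbers for more inhibition of growth at the one concentration tested:

Compound 1, `COc1ccc(Cc2nnc(NC(=O)/C(C#N)=C/c3ccccc3OS(=O)(=O)c3ccccc3[N+](=O)[O-])s2)cc1`, gives 25%.
Compound 2, `COc1ccc(Cc2nnc(NC(=O)/C(C#N)=C/c3ccccc3OS(=O)(=O)c3ccc(Cl)cc3)s2)cc1`, gives 20%.
Compound 3, `N#C/C(=C\c1ccccc1OS(=O)(=O)c1ccccc1[N+](=O)[O-])C(=O)Nc1nnc(Cc2ccccc2)s1`, gives 12%.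

Compound 4, `N#C/C(=C\c1ccccc1OS(=O)(=O)c1ccc(Cl)cc1)C(=O)Nc1nnc(Cc2ccccc2)s1`, has not yet been measured in this assay. It is derived from compound 3 by the change (4-chlorophenyl in place of 2-nitrophenyl on a sulfonyl sulfur). The same change, (4-chlorophenyl in place of 2-nitrophenyl on a sulfonyl sulfur), leads from compound 1 to compound 2, where it gave a number 5 percentage points lower from compound 1 to compound 2 (within the scatter). The place of the change reads the same word for word in both pairs, so it is the same change carried out on a different core. The cores of compound 1 and compound 3 differ by hydrogen in place of methoxy on an aromatic carbon, and that difference gave a number 13 percentage points lower from compound 1 to compound 3 (beyond the scatter). Compound 4 is therefore expected to end up close to compound 3. The estimated step is a number 3 percentage points lower from compound 3 to compound 4 (within the scatter), expected because a number 5 percentage points lower from compound 1 to compound 2 (within the scatter) lies within the scatter. For compound 4 the estimate in this assay is 9%, with a range from 0% to 22%. This estimate rests on compound 3 at 12% and on the earlier step of a number 5 percentage points lower from compound 1 to compound 2 (within the scatter).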

Compound 4, percent growth inhibition at one concentration: 26%
Beside the measured number, compound 4's estimate is 17 percentage points below it; measured number outside the range, above it.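

In this assay, 4-chlorophenyl in place of 2-nitrophenyl on a sulfonyl sulfur gave a number 14 percentage points higher from compound 3 to compound 4 (beyond the scatter), so this change did not carry over unaltered from the core of compound 1 to the core of compound 3: the same change on two cores in this assay, a number 5 percentage points lower (within the scatter) from compound 1 to compound 2 and a number 14 percentage points higher (beyond the scatter) from compound 3 to compound 4, 19 percentage points apart, beyond the scatter of two such steps. Hydrogen in place of methoxy on an aromatic carbon gave a number 6 percentage points higher from compound 2 to compound 4 (within the scatter), so that change also read differently depending on the group on the sulfonyl sulfur: the same change on two cores in this assay, a number 13 percentage points lower (beyond the scatter) from compound 1 to compound 3 and a number 6 percentage points higher (within the scatter) from compound 2 to compound 4, 19 percentage points apart, beyond the scatter of two such steps. These four compounds show that the two changes do not simply add up here, but they do not show why, or how either change would behave on a further core.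

They leave open how a methyl group on the sulfonyl sulfur, or a phenyl carrying an amine there, would compare with these two phenyl groups, and how a carboxylic acid would read in the place of the methoxy. With readings at only one concentration, they also leave open how growth inhibition changes with concentration.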